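This account rests on a few compounds, and the source may have more. Where it says the series, first, only, none or still open, it means among the compounds named here.

In a physicochemical assay for metabolic stability, read by LC-MS, with a stated time of 38 days, tested at 10 mM (a lower number here means that less of the compound is left, a higher number that more of the compound is left), compound 1 (`c1coc(-c2ccc3ccccc3n2)c1`) reads 117% and compound 2 (`Cc1ccc(-c2cc(C(=O)NC(C)C3CCCO3)c3ccccc3n2)o1`) reads 55% on the same scale. Compound 2 thus holds the lower of the two numbers, and its gap to compound 1 lies beyond the usual scatter of repeated measurements. These two compounds differ in more than one place, so their gap cannot be tied to any single change. In this assay compound 3 (`Cc1cccc(NC(=O)c2cc(-c3ccc(C)o3)nc3ccccc23)n1`) has not yet been measured. It departs from compound 2 only on the amide-type nitrogen, and the change is 6-methylpyridin-2-yl in place of 1-(oxolan-2-yl)ethyl on an amide-type nitrogen with the rest of the structure untouched. Among the measured compounds shown here, no measured pair shows this change, so the expectation rests on little. For the measured compounds named here, with compound 2 at 55% as the starting point and compound 1 at 117% as the only higher reading, a small upward move is expected, probably not beyond the scatter. The estimated step is a number 10 percentage points higher from compound 2 to compound 3 (within the scatter) with wide uncertainty. The estimate for compound 3 is 65% within an expected range of 40% to 90% on this read-out.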

Compound 3, percent of the compound remaining: 73%
For compound 3 the middle estimate is 8 percentage points below the measured one, within the range that was stated.
By their numbers in this assay, from the lowest: compound 2; then compound 3; then compound 1.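

In this assay, 6-methylpyridin-2-yl in place of 1-(oxolan-2-yl)ethyl on the amide-type nitrogen gives a number 18 percentage points higher from compound 2 to compound 3 (beyond the scatter). Among the compounds shown here, this is the first comparison here that differs in one place only, and it shows that the read-out responds to the group on this nitrogen, even though the two groups match in heavy atoms, hydrogen-bond donors, hydrogen-bond acceptors and net charge, and differ in the ring they carry and its hetero atom: a five-membered non-aromatic ring with oxygen leaves, and a six-membered aromatic ring with nitrogen enters. Nothing available explains why the reading moved with this exchange.

The compounds shown leave open which part of the entering group goes with the higher reading: the aromatic ring, its ring nitrogen or its methyl. A plain phenyl or a pyridin-2-yl without the methyl on the same nitrogen would separate these parts, while a simple open chain such as isopropyl would show whether the oxolane ring of the leaving group matters at all.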